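Methoxy on the aryl ring of a thiosemicarbazone

The compounds below may be only part of what the source reports. "The series", "measured", "known", "first", "only" and "open" are said of these compounds alone.

Compound 1 `CC1=CC[C@H](C(C)(C)NC(=S)NN)CC1` is the smallest member of this set; in an ADME assay on Vero cells (Chlorocebus sabaeus) for inhibition, read by sulforhodamine B assay, with a stated time of 48 h (on this read-out higher numbers stand for weaker inhibition of growth and lower numbers for stronger inhibition of growth), compound 1 gives 49500 nM. Compound 2 `CC1=CC[C@H](C(C)(C)NC(=S)N/N=C(\C)c2ccccc2)CC1` carries the same core joined to a phenyl-bearing hydrazone. In this assay compound 2 gives only a limit, > 100000 nM, and no number. This is the situation described by the limit of > 100000 nM in this assay, at which 1 of the 2 values shown sits: one of the two values shown sits at that limit, so where compound 2 stands can be stated only as a range. Compound 3 `COc1ccc(/C(C)=N/NC(=S)NC(C)(C)[C@H]2CC=C(C)CC2)cc1` differs from compound 2 by methoxy in place of hydrogen on an aromatic carbon. Among the compounds with values here, no measured step between two compounds separates this change from the rest, so there is no direct guide to its size. The expected step in this assay from compound 2 to compound 3 is a step that the limit leaves unreadable from compound 2 to compound 3, with no change beyond the scatter anticipated. Compound 3 is therefore estimated at 130000 nM, within a range from 60000 nM to 300000 nM, most likely again reported only as a limit.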

Compound 3, concentration for 50% growth inhibition: > 100000 nM
Compound 3 ended at the assay's limit (the forecaster's own chance of this, stated with the estimate: 70%); the middle value does not contradict the limit.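

No step can be read from compound 2 to compound 3, because both compounds give only a limit: the limit of > 100000 nM in this assay, at which 2 of the 3 values shown sit.

The compounds shown leave open whether going from phenyl to 4-methoxyphenyl changes growth inhibition at all, and in which direction.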